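Chloro to bromo swap on the anilide ring, cytotoxicity notes

The source may report more compounds than this note shows. Statements on the series, on what has been measured and on what is new or still open speak of the compounds shown alone.

Compound 1 `O=C(Nc1ccc(Cl)cc1)c1c(NO)cc(-c2cccs2)oc1=O` carries a hydroxyamino group and a thienyl ring on its core, with a 4-chlorophenyl amide. In an ADME assay on Huh-7 cells (Homo sapiens) for cytotoxicity, with a stated time of 3 days (on this read-out higher numbers stand for lower toxicity in this test and lower numbers for higher toxicity in this test), compound 1 gives only a limit, > 20000 nM. Compound 2 `O=C(Nc1ccc(Br)cc1)c1c(NO)cc(-c2cccs2)oc1=O` is its 4-bromophenyl counterpart, the change being (bromo in place of chloro on an aromatic carbon). In this assay compound 2 likewise gives only a limit, > 20000 nM. The step that the two limits leave unreadable from compound 1 to compound 2 is therefore unreadable; both values sit at the limit of > 20000 nM in this assay, at which 2 of the 3 values shown sit, so no size can be assigned to the swap on this pair.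

Compound 3 `O=C(Nc1ccc(Cl)cc1)c1c(NCCO)cc(-c2cccc(Br)c2)oc1=O` has a different core, with a 2-hydroxyethylamino group and a 3-bromophenyl ring in place of the thienyl ring; the difference between the two cores is not broken down here. In this assay, for the measured compounds named here, compound 3 gives 17000 nM, the only number among the three measured values.

Compound 4 `O=C(Nc1ccc(Br)cc1)c1c(NCCO)cc(-c2cccc(Br)c2)oc1=O` is not yet measured. It differs from compound 3 by bromo in place of chloro on an aromatic carbon, the same change as that from compound 1 to compound 2, on a place described in the same words. The measured pair gives no readable size for this change. The expectation for compound 4 therefore rests on compound 3, which gives 17000 nM in this assay. It also rests on the observation that compound 1 and compound 2 were not separated from each other on this read-out.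

The step of no change at the digits printed from compound 3 to compound 4 (within the scatter) is expected to be small. Compound 4 is therefore estimated at 17000 nM in this assay, with a likely range from 7000 nM to 40000 nM, and a fair chance that only a limit is reported.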

Compound 4, half-maximal cytotoxic concentration: > 20000 nM
Compound 4: no number, only a limit (the forecaster's own chance of this, stated with the estimate: 45%); at least 1.1-fold (0.07 log units) between middle value and limit.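

Carried from the core of compound 1 to the core of compound 3, bromo in place of chloro on the anilide ring gives in this assay an at least 1.1-fold higher number from compound 3 to compound 4 (0.07 log units; that floor lies within the scatter), so the step has only a floor and its true size stays open. For the compounds shown here, what this shows is narrow: on both cores the 4-bromophenyl compound ends in a limit rather than a number, while the only number belongs to a 4-chlorophenyl compound, and that one core-to-core observation rests on just these two pairs. It does not show that the change has the same size on both cores, since the step on the first pair cannot be read and the second has no upper bound, leaving two sizes that cannot be compared, and the read-out offers little room for such a comparison: the limit of > 20000 nM in this assay, at which 3 of the 4 values shown sit.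

Still open, as far as these compounds go, is how this read-out responds on the anilide ring to a group that is not a halogen, such as an amine or a carboxylic acid in place of the bromo. Also open, from the compounds shown here alone, is whether a longer chain in place of the 2-hydroxyethylamino group would shift the values of the core of compound 3 to numbers that can be read.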